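A few compounds are considered here, and "the series" means these few. Any claim that something is new, unique, unknown or untested is made for them only; others in the source may bear on it.

In a functional assay on HeLa cells (Homo sapiens) for antiproliferative activity, read by sulforhodamine B assay, with a stated time of 48 h (on this read-out higher numbers stand for weaker inhibition and lower numbers for stronger inhibition), compound 1 (`COc1ccc(C[C@@H](O)/C=C/C=C/C(=O)N2CCN(C)CC2)cc1OC`) gives 16500 nM. Compound 2 (`COc1ccc(C[C@@H](O)/C=C/C=C/C(=O)NCc2ccccc2)cc1OC`) gives 12900 nM. Among the compounds with values here, these are the only two numbers so far, and they cannot be told apart, so compound 1 sits level with the only other measured compound. Compound 3 (`COc1ccc(C[C@@H](O)/C=C/C=C/C(=O)N2CCN(c3ncccn3)CC2)cc1OC`) has pyrimidin-2-yl in place of methyl on an amine nitrogen in a ring. Within the data shown here, no measured step makes this exact change. The nearest guide changes the group on the carbonyl carbon, where benzylamino in place of 4-methylpiperazin-1-yl gave a 1.3-fold lower number from compound 1 to compound 2 (0.11 log units; within the scatter). That single step is weak evidence, but it offers no reason to expect a shift beyond the scatter in this assay, in either direction. The estimated step is a 1.3-fold lower number from compound 1 to compound 3 (0.10 log units; within the scatter). For compound 3 the expected value is 13000 nM, with an estimated range from 5500 nM to 30000 nM.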

Compound 3, half-maximal inhibitory concentration: 12600 nM
Estimate against measurement, compound 3: 1.0-fold (0.01 log units) above; the range from low to high includes it.
By their numbers in this assay, from the lowest: compounds 3, 2 and 1 (each within the scatter of the next).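

In this assay, putting pyrimidin-2-yl in place of methyl on the ring amine nitrogen gives a 1.3-fold lower number from compound 1 to compound 3 (0.12 log units; within the scatter). The earlier step exchanged the whole group on the carbonyl carbon, whereas this one keeps the ring and shows that a much larger group bringing an aromatic ring and hydrogen-bond acceptors can sit on this nitrogen without a shift beyond the scatter. No measurement is available to explain this result.

On these data alone, it remains open whether a plain hydrogen, a phenyl ring or a carboxylic acid on this nitrogen would also stay within the scatter of compound 1. The steps shown so far include no change that moves the number beyond the scatter, so they do not yet reveal which changes at this position matter.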